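The source may hold more compounds than are shown below. What is called first, only, known or untested is meant among the compounds shown, and "the series" means these compounds.

Measured so far:
compound 1 `NC(=S)N/N=C1/C(=O)N(CN2CCN(c3ccnc4cc(Cl)ccc34)CC2)c2cccc(Br)c21` — 46600 nM
compound 2 `NC(=S)N/N=C1/C(=O)N(CN2CCN(c3ccnc4cc(C(F)(F)F)ccc34)CC2)c2cccc(Cl)c21` — 21600 nM

In a functional assay on MCF7 cells (Homo sapiens) for cytotoxicity, read by sulforhodamine B assay, with a stated time of 48 h (a lower number here means a stronger inhibitor of growth, a higher number a weaker inhibitor of growth), compound 2 gives 21600 nM, the lower of the two numbers. Among the measured compounds shown here, compound 1 gives 46600 nM, a higher number that lies beyond the scatter of the method; the two compounds differ in more than one place, however, and no single step between them is available. Compound 3 `NC(=S)N/N=C1/C(=O)N(CN2CCN(c3ccnc4cc(C(F)(F)F)ccc34)CC2)c2cccc(Br)c21`, not yet measured, follows from compound 2 by bromo in place of chloro on an aromatic carbon. For the measured compounds named here, no measured pair shows this change by itself, so its size is unknown here. Because compound 2 already sits at 21600 nM, the exchange of one halogen for another on that aromatic carbon is expected to shift the number little in this assay, in no clear direction and within the scatter. The step of a 1.2-fold higher number from compound 2 to compound 3 (0.06 log units; within the scatter) is expected to be small. Compound 3 is estimated at 25000 nM, with a range from 10000 nM to 60000 nM.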

Compound 3, concentration for 50% growth inhibition: 50600 nM
The estimate for compound 3 lay 2.0-fold (0.31 log units) below the measured number; the measured number falls inside the stated range.
By their numbers in this assay, from the lowest: compound 2; then compounds 1 and 3 (each within the scatter of the next).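

In this assay, the halogen on this aromatic carbon proves to be a change that can be read: bromo in place of chloro gives a 2.3-fold higher number from compound 2 to compound 3 (0.37 log units; beyond the scatter), with the trifluoromethyl group held constant. The other exchange behaves differently: with bromo in place, trifluoromethyl in place of chloro on a different aromatic carbon gives a 1.1-fold higher number from compound 1 to compound 3 (0.04 log units; within the scatter), so that exchange shows no difference beyond the scatter in this pair. Nothing available here explains why the halogen exchange shifts the number.

On these data alone, each change rests on a single pair, so it remains open whether the halogen step would have the same size with chloro instead of trifluoromethyl on the other aromatic carbon. Also open, as far as these compounds go, is how a fluoro group, a methoxy group or an amine would read on the carbon that carries the halogen.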